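A few compounds are considered here, and "the series" means these few. Any claim that something is new, unique, unknown or untested is made for them only; others in the source may bear on it.

Measured compounds:
compound 1, `CC(C)(C)c1cc(NC(=O)Nc2ccc(F)cc2)n(-c2ccccc2)n1`: 7.4 degrees C
compound 2, `Cn1nc(-c2ccccc2)cc1NC(=O)Nc1cc(C(F)(F)F)cc(C(F)(F)F)c1`: 1.9 degrees C
compound 3, `CC(C)(C)c1cc(NC(=O)Nc2ccc(Cl)cc2)n(-c2ccc(C(F)(F)F)cc2)n1`: 0.7 degrees C

In an assay on isolated protein for inhibition of STE20-like serine/threonine-protein kinase (Homo sapiens), read by thermal shift assay, tested at 10 uM (on this read-out higher numbers stand for stronger stabilisation of the target against heat and lower numbers for weaker stabilisation of the target), compound 3 stands lowest of the three numbers. Its nearest neighbour is compound 2, whose value of 1.9 degrees C lies above it by more than the usual scatter, and the furthest is compound 1, whose value of 7.4 degrees C lies far above it. For the measured compounds named here, no pair of measured compounds differs in only one place, so these values can be compared only as they stand and no single step can be isolated from them.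

Compound 4, `CC(C)(C)c1cc(NC(=O)Nc2ccc(Cl)cc2)n(-c2ccc(NC(=O)C3CC3)cc2)n1`, arises from compound 3 by one change: (cyclopropylcarbonyl)amino in place of trifluoromethyl on an aromatic carbon, para to a large group. No measured pair matches this exchange, so the size of the step in this assay has no precedent among the numbers shown. Going by the values given here, a modest upward step is nonetheless expected, since the only compound without a trifluoromethyl group, compound 1, gives 7.4 degrees C. The step from compound 3 to compound 4 is expected to be a number 1.8 degrees C higher from compound 3 to compound 4 (beyond the scatter). Compound 4 is therefore estimated at 2.5 degrees C, within a range from 0 degrees C to 6 degrees C.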

Compound 4, shift of the target's melting temperature: 4.1 degrees C
Compound 4: middle estimate off by 1.6 degrees C, on the low side; the range from low to high includes it.
By their numbers in this assay, from the lowest: compound 3; then compound 2; then compound 4; then compound 1.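

In this assay, for the compounds shown here, the exchange of trifluoromethyl for (cyclopropylcarbonyl)amino on an aromatic carbon, para to a large group, gives a number 3.4 degrees C higher from compound 3 to compound 4 (beyond the scatter) and is the first step that can be read at a single place. It shows that this position responds to what it carries, and that the stabilisation of the target rises, rather than being lost, when a group with more heavy atoms, a three-membered ring, a hydrogen-bond donor and a hydrogen-bond acceptor enters there. No measurement bears on why the number rises, so the step stands as an observation without an explanation.

The compounds shown do not separate the contribution of the cyclopropyl ring from that of the amide, and a plain amine or an acetylamino group at this position would be needed to tell the two apart. Going by these compounds, it also remains open how a carboxylic acid or a longer chain on the same carbon would compare, and whether the step would carry over to a core with different groups elsewhere.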